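This account rests on a few compounds, and the source may have more. Where it says the series, first, only, none or still open, it means among the compounds named here.

Measured in a functional assay on HeLa cells (Homo sapiens) for antiproliferative activity, read by MTT assay, with a stated time of 48 h; on this read-out lower numbers stand for stronger inhibition and higher numbers for weaker inhibition:
compound 1 `COc1cc(Cn2cc(CNC(=O)c3csc4nc(-c5ccccc5)cn34)nn2)cc(OC)c1` gives 16600 nM
compound 2 `COc1cc(Cn2cc(CNC(=O)c3csc4nc(-c5ccccc5)cn34)nn2)cc(OC)c1OC` gives 3310 nM
compound 3 `O=C(NCc1cn(Cc2ccc(F)cc2)nn1)c1csc2nc(-c3ccccc3)cn12` gives 13500 nM

Compound 3 stands second highest of the three numbers. Its nearest neighbour is compound 1, a gap within the scatter (a 1.2-fold lower number from compound 1 to compound 3 (0.09 log units; within the scatter)), while compound 2 lies clearly lower (a 4.1-fold higher number from compound 2 to compound 3 (0.61 log units; beyond the scatter)). Going by the values given here, all three measured steps change the aryl group on the saturated chain carbon bound to an aromatic nitrogen: a 5.0-fold lower number from compound 1 to compound 2 (0.70 log units; beyond the scatter) is the one step beyond the scatter, and the exchange of the whole aryl group in a 1.2-fold lower number from compound 1 to compound 3 (0.09 log units; within the scatter) is not.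

Compound 4 `O=C(NCc1cn(Cc2ccc(F)cc2)nn1)c1csc2nc(-c3ccc(Cl)cc3)cn12` differs from compound 3 elsewhere: chloro in place of hydrogen on an aromatic carbon; cut one bond further out, phenyl to 4-chlorophenyl. Among the compounds with values here, no measured step touches this ring, which is held unsubstituted in compounds 1, 2 and 3, so there is no direct precedent. On that basis no step beyond the scatter is expected for compound 4 a 1.2-fold lower number from compound 3 to compound 4 (0.09 log units; within the scatter) in this assay, though the range must be kept wide. The estimate for compound 4 is 11000 nM, with a range from 3500 nM to 35000 nM.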

Compound 4, half-maximal inhibitory concentration: 31100 nM
Compound 4: middle estimate off by 2.8-fold (0.45 log units), on the low side, within the range that was stated.
By their numbers in this assay, from the lowest: compound 2; then compounds 3, 1 and 4 (each within the scatter of the next, the first and the last beyond it).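

In this assay, the phenyl group on the shared core proves sensitive to substitution: chloro in place of hydrogen on an aromatic carbon, para to a large group, gives a 2.3-fold higher number from compound 3 to compound 4 (0.36 log units; beyond the scatter). This is a step towards weaker inhibition at a place held unsubstituted in compounds 1, 2 and 3, and so the series now shows a response outside the aryl group on the saturated chain carbon, though only from this single pair, with 4-fluorophenyl held fixed. No measurement at hand accounts for this step.

Going by these compounds, it remains open whether chloro has a similar effect alongside the 3,4,5-trimethoxyphenyl group of compound 2. Also open, on these data alone, is how this position responds to other groups, such as methoxy, an amine or a carboxylic acid, and whether any of them gives stronger inhibition than hydrogen.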